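This account rests on a few compounds, and the source may have more. Where it says the series, first, only, none or still open, it means among the compounds named here.

Working notes on the series. Among the compounds with values here, the shared core carries a urea-type carbonyl whose substituent is the only variable across compound 1 `COC1CCN(C(=O)N2CC(c3nc(-c4cccc(Cl)c4)no3)C2)CC1`, compound 2 `CC1CCC(C(=O)N2CC(c3nc(-c4cccc(Cl)c4)no3)C2)CC1` and compound 3 `CC1CN(C(=O)N2CC(c3nc(-c4cccc(Cl)c4)no3)C2)CC(C)O1`. In an assay on HEK293 cells for negative allosteric modulation of metabotropic glutamate receptor 5 (Homo sapiens), read by FLIPR (a lower number here means a stronger inhibitor, a higher number a weaker inhibitor), compound 1 sits at a limit of the assay, > 10000 nM. Compound 2 likewise sits at a limit, > 10000 nM. Within the data shown here, compound 3 is the sole member with a number, 990 nM, and so stands as the only readable point. The two steps toward it, an at least 10-fold lower number from compound 1 to compound 3 (1.00 log units; beyond the scatter) and an at least 10-fold lower number from compound 2 to compound 3 (1.00 log units; beyond the scatter), are at least modest, their true size open-ended because of the limit of > 10000 nM in this assay, at which 2 of the 3 values shown sit. Compound 4 `O=C(N1CCCCC1)N1CC(c2nc(-c3cccc(Cl)c3)no2)C1` differs from compound 3 by piperidin-1-yl in place of 2,6-dimethylmorpholin-4-yl on a carbonyl carbon. Among the measured compounds shown here, no measured step removes the ring oxygen and the two methyls together; the nearest comparisons are the other saturated six-membered groups, on compound 1 and compound 2, neither of which gave a number. In this assay the expected step is therefore a 5.1-fold higher number from compound 3 to compound 4 (0.70 log units; beyond the scatter), upward. Compound 4 is estimated at 5000 nM (range 1500 nM to 20000 nM), with a fair chance that only a limit is returned.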

Compound 4, half-maximal inhibitory concentration: > 10000 nM
Compound 4 gave a limit, no number (the forecaster's own chance of this, stated with the estimate: 45%); middle value at least 2.0-fold (0.30 log units) from the limit.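

On a carbonyl carbon in this assay, the change to piperidin-1-yl is an at least 10-fold higher number from compound 3 to compound 4 (1.00 log units; beyond the scatter), so the readable activity of compound 3 does not survive losing the ring oxygen and the two methyls together. Replacing the methoxy of compound 1 with hydrogen also brings back no number, so the bare piperidin-1-yl ring gives no readable activity here, and 2,6-dimethylmorpholin-4-yl on compound 3 remains the only group shown that does. The steps among compound 1, compound 2 and compound 4 cannot be read, and the size of the loss stays open-ended: the limit of > 10000 nM in this assay, at which 3 of the 4 values shown sit.

The compounds shown do not separate the ring oxygen from the two methyls. Unsubstituted morpholin-4-yl, which keeps the oxygen, and a dimethylpiperidin-1-yl, which keeps the methyls, would tell the two contributions apart.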